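Thiophene for phenyl at the chain carbon of compound 3

The source may report more compounds than this note shows. Statements on the series, on what has been measured and on what is new or still open speak of the compounds shown alone.

Compound 3 `CC(CC(=O)/N=C(\N)NCCCc1ncc[nH]1)c1ccccc1` gives 5.3 in a functional assay on Sf9 cells for antagonist activity at histamine H2 receptor (Homo sapiens), with stated times of 2 min and 20 min (a higher number here means a more potent compound, by a factor of ten per unit of this negative logarithm, a lower number a less potent compound), and stands lowest of the three numbers here. Compound 1 `CC(CC(=O)/N=C(\N)NCCCc1ccncc1)c1ccccc1` gives 5.54; the step of a number 0.24 log units lower from compound 1 to compound 3 (within the scatter) lies within the scatter. Compound 2 `CC(CC(=O)/N=C(\N)NCCCc1ccc(CN(C)C)o1)c1ccccc1` gives 6.52, and the step of a number 1.22 log units lower from compound 2 to compound 3 (beyond the scatter) is large, as is a number 0.98 log units higher from compound 1 to compound 2 (beyond the scatter). Compound 4 `CC(CC(=O)/N=C(\N)NCCCc1ncc[nH]1)c1cccs1` carries thiophen-2-yl in place of phenyl on a saturated chain carbon bound to two saturated chain carbons. Going by the values given here, none of the measured steps touches that part of the molecule; all three vary the group three bonds along the chain from an amine nitrogen. Among the compounds with values here, no measured step therefore bears on this change, and no step beyond the scatter is expected in this assay in either direction. Compound 4 is expected to give 5.3, within 4.8 to 5.8, an expected step of no change at the digits printed from compound 3 to compound 4 (within the scatter).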

Compound 4, negative logarithm of the antagonist equilibrium constant: 5.26
For compound 4 the middle estimate is 0.04 log units above the measured one, and the stated range covers the measured number.
By their numbers in this assay, from the lowest: compounds 4, 3 and 1 (each within the scatter of the next); then compound 2.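

Going by these compounds alone, the exchange of phenyl for thiophen-2-yl on a saturated chain carbon bound to two saturated chain carbons is the first change read at this place, and this assay records a number 0.04 log units lower from compound 3 to compound 4 (within the scatter) for it. With 1H-imidazol-2-yl kept, this place therefore accepts either aromatic ring without a step beyond the scatter. Nothing measured here explains why the two rings read alike.

From the compounds shown here alone, whether the exchange holds alongside 5-((dimethylamino)methyl)furan-2-yl, the group of compound 2, remains open. So does the outcome with a saturated ring such as cyclohexyl or a simple methyl group at this carbon.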